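The compounds below may be only part of what the source reports. "The series", "measured", "known", "first", "only" and "open" are said of these compounds alone.

Compound 3 `CCCCCC(=O)n1c(=S)oc2ccccc21` gives 130000 nM in a physicochemical assay for solubility (on this read-out lower numbers stand for lower solubility and higher numbers for higher solubility), the second highest of the three numbers measured. Compound 1 `O=C(/C=C/c1ccccc1)n1c(=S)oc2ccccc21` gives 80000 nM, a number within the scatter of compound 3. Compound 2 `CC(=O)n1c(=S)[nH]c2ccccc21` gives 460000 nM, which lies beyond the scatter above compound 3. Compound 4 `O=C(CCCc1ccccc1)n1c(=S)oc2ccccc21` has not yet been measured; it differs from compound 3 by phenyl in place of ethyl on a saturated chain carbon, three bonds along the chain from a carbonyl carbon. No step between the measured compounds matches this change, so any expectation rests on the three numbers shown. Compound 1 also carries a phenyl and gives 80000 nM. A modest downward step is expected in this assay, a 2.2-fold lower number from compound 3 to compound 4 (0.34 log units; beyond the scatter), at the edge of the scatter. Compound 4 is therefore estimated at 60000 nM, in the range 20000 nM to 180000 nM.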

Compound 4, solubility: 100000 nM
For compound 4 the middle estimate is 1.7-fold (0.22 log units) below the measured one; low and high end bracket the measured number.
By their numbers in this assay, from the lowest: compounds 1, 4 and 3 (each within the scatter of the next); then compound 2.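

In this assay, for the compounds shown here, the step of a 1.3-fold lower number from compound 3 to compound 4 (0.11 log units; within the scatter) gives the first reading at this place on the chain: phenyl in place of ethyl, three bonds along the chain from a carbonyl carbon, leaves the two compounds indistinguishable. An aromatic ring can thus enter at this saturated chain carbon with no change beyond the scatter. Nothing shown accounts for this result. As far as these compounds go, whether an amine or a carboxylic acid at the same place would also stay within the scatter remains open, as does the effect of a longer chain.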